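This account rests on a few compounds, and the source may have more. Where it says the series, first, only, none or still open, it means among the compounds named here.

Of the compounds shown here, three have so far been tested in an ADME assay on HEK293 cells (Homo sapiens) for antiproliferative activity, read by MTT assay, with a stated time of 24 h; a higher number here means a weaker inhibitor, a lower number a stronger inhibitor. Compound 1 `COc1cc(-c2cc(C(=O)/C=C/c3ccc(Cl)cc3)nc3cc(-c4ccccc4)nn23)cc(OC)c1OC` gives 53900 nM in this assay. Compound 2 `COc1ccc(/C=C/C(=O)c2cc(-c3cc(OC)c(OC)c(OC)c3)n3nc(-c4ccccc4)cc3n2)cc1OC` gives 41000 nM in this assay. Compound 3 `COc1ccc(C(=O)/C=C/c2cc(-c3cc(OC)c(OC)c(OC)c3)n3nc(-c4ccccc4)cc3n2)cc1OC` gives 81700 nM in this assay, and its number lies within the scatter of both others. Compound 1 differs from compound 2 by 4-chlorophenyl in place of 3,4-dimethoxyphenyl on a double-bonded chain carbon bound to a double-bonded chain carbon, and that change made a 1.3-fold higher number from compound 2 to compound 1 (0.12 log units; within the scatter). Compound 3 and compound 2 hold the same atoms joined differently; the difference between the two cores is not broken down here.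

Compound 4 `COc1cc(-c2cc(/C=C/C(=O)c3ccc(Cl)cc3)nc3cc(-c4ccccc4)nn23)cc(OC)c1OC` has not yet been measured. It differs from compound 3 by 4-chlorophenyl in place of 3,4-dimethoxyphenyl on a carbonyl carbon. This is the same kind of change as that from compound 2 to compound 1, but not the same: there the group sits on a double-bonded chain carbon bound to a double-bonded chain carbon, whereas here it sits on a carbonyl carbon whose other neighbour is a double-bonded chain carbon. Because the earlier step of a 1.3-fold higher number from compound 2 to compound 1 (0.12 log units; within the scatter) stayed within the scatter, a similarly small step a 1.2-fold higher number from compound 3 to compound 4 (0.07 log units; within the scatter) is expected. Compound 4 is therefore estimated at 95000 nM, with a likely range from 45000 nM to 200000 nM.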

Compound 4, half-maximal inhibitory concentration: >= 100000 nM
Compound 4 was reported as a limit (the forecaster's own chance of this, stated with the estimate: 15%); middle value at least 1.0-fold (0.02 log units) away from the limit.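

In this assay compound 4 is given only as a limit, >= 100000 nM, and not as a number. Its steps can therefore be read only as floors: an at least 1.2-fold higher number from compound 3 to compound 4 (0.08 log units; that floor lies within the scatter) for 4-chlorophenyl in place of 3,4-dimethoxyphenyl on a carbonyl carbon, and an at least 1.8-fold higher number from compound 1 to compound 4 (0.26 log units; that floor lies within the scatter) for 2-((4-chlorophenyl)carbonyl)ethenyl in place of (2-(4-chlorophenyl)ethenyl)carbonyl on an aromatic carbon. As far as these floors go, the exchange of the two phenyl groups gives no step beyond the scatter on either core, but its true size on the core of compound 3, and so whether it carries over unchanged, remains undecided: the same change on two cores in this assay, a 1.3-fold higher number (0.12 log units; within the scatter) from compound 2 to compound 1 and an at least 1.2-fold higher number (0.08 log units; that floor lies within the scatter) from compound 3 to compound 4; the limit leaves it open whether they differ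

The compounds shown leave open how the core of compound 3 would read with a group other than these two on the carbonyl carbon, such as an amine or a carboxylic acid on the phenyl ring. They also leave open how a longer chain in place of the ethenyl would read in this assay.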